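From benzoyl to bromo in a growth inhibition series

The source may report more compounds than this note shows. Statements on the series, on what has been measured and on what is new or still open speak of the compounds shown alone.

Compound 1 `C=CCc1ccc(OCc2cn(-c3ccccc3CO)nn2)c(O)c1` gives 31.7%
Compound 2 `C=CCc1ccc(OCc2cn(-c3ccc(C(=O)c4ccccc4)cc3)nn2)c(O)c1` gives 38.3%

In a functional assay on HL-60 cells (Homo sapiens) for inhibition, read by MTT assay, with a stated time of 72 h, tested at 30 uM (a higher number here means more inhibition of growth at the concentration tested, a lower number less inhibition of growth), compound 2 gives 38.3% and so stands within the usual scatter of compound 1 at 31.7% in this small set. Neither of the two can be ranked over the other on these numbers.

Compound 3 `C=CCc1ccc(OCc2cn(-c3ccc(Br)cc3)nn2)c(O)c1` has no value yet in this assay and differs from compound 2 in one place. The change bromo in place of benzoyl on an aromatic carbon is bromo in place of benzoyl on an aromatic carbon, para to a large group. Among the compounds with values here, no step between measured compounds that differ in one place is available, so the data do not show how much a single change moves this read-out. Within the data shown here, the only guide is the pair of values for compound 1 at 31.7% and compound 2 at 38.3% which lie close together.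

The estimated step of a number 3.3 percentage points lower from compound 2 to compound 3 (within the scatter) is therefore expected to stay within the scatter, with no clear direction. For compound 3 the estimated value is 35% with an expected range from 20% to 52% in this measurement.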

Compound 3, percent growth inhibition at one concentration: 22.1%
The estimate for compound 3 lay 12.9 percentage points above the measured number; low and high end bracket the measured number.
By their numbers in this assay, from the lowest: compounds 3, 1 and 2 (each within the scatter of the next, the first and the last beyond it).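

Read in this assay the exchange of benzoyl for bromo on an aromatic carbon, para to a large group, supplies a step between compounds that differ in one place (a number 16.2 percentage points lower from compound 2 to compound 3 (beyond the scatter)), and this step lies beyond the scatter. This position therefore responds to the group it carries, if only modestly, which the close pair of compound 1 and compound 2 could not show. The change of the whole group on the aromatic nitrogen, 4-bromophenyl in place of 2-(hydroxymethyl)phenyl, gives a smaller step (a number 9.6 percentage points lower from compound 1 to compound 3 (within the scatter)) that stays within the scatter, so it sets no order between those two compounds. No evidence at hand explains either step.

With only benzoyl and bromo compared on this carbon, the compounds shown leave open whether an amine, a carboxylic acid or a longer chain there would read nearer compound 2 or nearer compound 3. They also leave open whether the step from benzoyl to bromo would be of the same size with 2-(hydroxymethyl)phenyl features elsewhere on the shared core.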